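Glycoside series: phenyl to pyridin-3-yl on the chain

This account rests on a few compounds, and the source may have more. Where it says the series, first, only, none or still open, it means among the compounds named here.

Of the compounds shown here, three of this glycoside series have numbers so far. Compound 1 `O=C(/C=C/c1ccccc1)C[C@@H]1O[C@H](CO)[C@@H](O[C@@H]2O[C@H](CO)[C@@H](O)[C@H](O)[C@H]2O)[C@H](O)[C@H]1O` carries an additional sugar on the core, and in an assay on isolated protein for inhibition of lysosomal alpha-glucosidase (Rattus norvegicus), tested at 100 uM (a higher number here means more inhibition at the concentration tested (going by the name of the read-out), a lower number less inhibition), compound 1 gives -24.6%. Compound 2 `O=C(/C=C/c1cccc([N+](=O)[O-])c1)C[C@@H]1O[C@H](CO)[C@@H](O)[C@H](O)[C@H]1O` has a single sugar, and in this assay compound 2 gives -10%. Compound 3 `CCOC(=O)C(C(=O)OCC)C(CC(=O)C[C@@H]1O[C@H](CO)[C@@H](O)[C@H](O)[C@H]1O)c1ccccc1` holds the diester branch on the chain, and in this assay compound 3 gives -45%. Among the three numbers compound 3 stands lowest; the nearest is compound 1, whose number is higher by an amount beyond the usual scatter, and the furthest is compound 2, whose number is higher by a larger amount, again beyond the scatter. All three numbers are negative, so none of the three shows inhibition at the concentration tested.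

Compound 4 `CCOC(=O)C(C(=O)OCC)C(CC(=O)C[C@@H]1O[C@H](CO)[C@@H](O)[C@H](O)[C@H]1O)c1cccnc1` is not yet measured. The change from compound 3 to compound 4 is pyridin-3-yl in place of phenyl on a saturated chain carbon bound to two saturated chain carbons. Among the measured compounds shown here, no pair of measured compounds shows this change, so no size can be read from the series. The expectation is a step in this assay of about a number 10 percentage points higher from compound 3 to compound 4 (within the scatter), small and not clearly beyond the scatter, in either direction. The estimate for compound 4 is -35%, within -65% to -5%.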

Compound 4, a percentage reported as inhibition, at one concentration (the size of the read-out at that concentration, not a potency): -20%
Beside the measured number, compound 4's estimate is 15 percentage points below it, and the stated range covers the measured number.
By their numbers in this assay, from the lowest: compound 3; then compounds 1, 4 and 2 (each within the scatter of the next, the first and the last beyond it).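

On the saturated chain carbon bound to two saturated chain carbons, pyridin-3-yl in place of phenyl gives the first step the series can read in this assay: a number 25 percentage points higher from compound 3 to compound 4 (beyond the scatter). The change replaces one ring carbon with nitrogen and brings in one hydrogen-bond acceptor, so this position responds to a single-atom change in the ring, yet compound 4 still gives -20%, and neither ring shows inhibition at the concentration tested. Nothing at hand accounts for the size of the step, which rests on this one pair of compounds.

As far as these compounds go, it remains open whether a saturated ring such as cyclohexyl, or a phenyl ring carrying an amine or a carboxylic acid, on this same chain carbon would move the number further or turn it positive. From the compounds shown here alone, it is also open whether pyridin-3-yl in place of phenyl would give a step of similar size with a different chain, such as the unsaturated chain of compound 1, or whether this step holds only alongside the diester branch.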